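Aryl swap on the benzyl ether of compound 3

The source may report more compounds than this note shows. Statements on the series, on what has been measured and on what is new or still open speak of the compounds shown alone.

Measured in a functional assay on MGC-803 cells (Homo sapiens) for inhibition, read by MTT assay, with a stated time of 48 h; on this read-out higher numbers stand for weaker inhibition and lower numbers for stronger inhibition:
- compound 1 `Cc1ccc(NC(=S)NC(=O)c2ccc(OCc3ccccc3)cc2)cc1-c1nc2ccccc2[nH]1`: 60700 nM
- compound 2 `Cc1ccc(NC(=S)NC(=O)c2ccc(OCc3cccc(Cl)c3)cc2)cc1-c1nc2ccccc2[nH]1`: 51300 nM
- compound 3 `Cc1ccc(NC(=O)NC(=O)c2ccc(OCc3cccc(Cl)c3)cc2)cc1-c1nc2ccccc2[nH]1`: 20800 nM

Compound 3 gives the lowest number of the three. Its gaps to compound 2 and to compound 1 are both beyond the scatter, with compound 2 nearer to it and compound 1 furthest. Within the data shown here, no single-change step joins compound 3 to either of them, so these gaps are taken only as what the two values show.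

Compound 4 `Cc1ccc(COc2ccc(C(=O)NC(=O)Nc3ccc(C)c(-c4nc5ccccc5[nH]4)c3)cc2)cc1` is compound 3 with one change: 4-methylphenyl in place of 3-chlorophenyl on a saturated chain carbon bound to an oxygen on an aromatic ring.

Among the measured compounds shown here, the only measured step that touches this ring is a 1.2-fold lower number from compound 1 to compound 2 (0.07 log units; within the scatter). That step, chloro in place of hydrogen on the same aromatic carbon, lies within the scatter, so on the evidence in hand a substituent change on this ring does not move this assay much. A change of substituent and of its place on the ring, chloro removed and methyl entering, is therefore expected to give no step beyond the scatter from compound 3 to compound 4.

For compound 4 the expected value in this assay is 25000 nM, with a range of 10000 nM to 60000 nM, corresponding to an estimated step of a 1.2-fold higher number from compound 3 to compound 4 (0.08 log units; within the scatter).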

Compound 4, half-maximal inhibitory concentration: 4250 nM
Beside the measured number, compound 4's estimate is 5.9-fold (0.77 log units) above it, outside the stated range (below it).
By their numbers in this assay, from the lowest: compound 4; then compound 3; then compounds 2 and 1 (each within the scatter of the next).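

In this assay, 4-methylphenyl in place of 3-chlorophenyl on a saturated chain carbon bound to an oxygen on an aromatic ring gives a 4.9-fold lower number from compound 3 to compound 4 (0.69 log units; beyond the scatter), so the aryl group at this place can move the number by more than the scatter. The earlier step, a 1.2-fold lower number from compound 1 to compound 2 (0.07 log units; within the scatter), did not show this: it lay within the scatter, involved chloro in place of hydrogen alone, and was read on compounds with a thiocarbonyl where compound 3 and compound 4 carry a carbonyl. No measurement in hand bears on what lies behind the new step.

The step changes the substituent and its place on the ring together, so the compounds shown leave open whether it follows from the methyl group, from its place or from the loss of chloro; 4-chlorophenyl and 3-methylphenyl on the same carbonyl-bearing scaffold would separate these readings. Also open, as far as these compounds go, is whether the step extends to other groups on this ring, such as a methoxy, an amine or a longer alkyl chain.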